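The source may hold more compounds than are shown below. What is called first, only, known or untested is meant among the compounds shown, and "the series" means these compounds.

Compound 1 `COc1ccccc1CNc1ncnc2c1ncn2C1CCCCO1` – 97000 nM
Compound 2 `COc1cccc(CNc2ncnc3c2ncn3C2CCCCO2)c1` – 61000 nM
Compound 3 `COc1cccc(OC)c1CNc1ncnc2c1ncn2C1CCCCO1` – 10300 nM

Of the compounds shown here, three have been measured in an ADME assay on K562 cells (Homo sapiens) for cytotoxicity, with a stated time of 72 h; a higher number here means a weaker inhibitor, a lower number a stronger inhibitor. Compound 1 gives 97000 nM, compound 2 gives 61000 nM and compound 3 gives 10300 nM. Compound 1 and compound 2 share the same atoms joined differently; the difference between the two cores is 3-methoxyphenyl in place of 2-methoxyphenyl on a saturated chain carbon bound to a nitrogen on an aromatic ring, and the step of a 1.6-fold lower number from compound 1 to compound 2 (0.20 log units; within the scatter) lies within the scatter, so the two cannot be ordered against each other.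

Compound 3 is made from compound 1 by the change (methoxy in place of hydrogen on an aromatic carbon). This change gave the step of a 9.4-fold lower number from compound 1 to compound 3 (0.97 log units; beyond the scatter), a modest move to a lower number.

Compound 4 `COc1cc(CNc2ncnc3c2ncn3C2CCCCO2)cc(OC)c1` has not yet been measured in this assay. It is made from compound 2 by the change (methoxy in place of hydrogen on an aromatic carbon). Within the data shown here, this is the same kind of change as the one from compound 1 to compound 3, with a difference around the place: in compound 3 the entering methoxy sits ortho to a large group, while in compound 4 it sits meta to a large group. Among the measured compounds shown here, because the earlier change gave a 9.4-fold lower number from compound 1 to compound 3 (0.97 log units; beyond the scatter), a step in the same direction is expected for compound 4, but with only one example at a different place the size is uncertain. For compound 4 a smaller step is therefore estimated, a 3.1-fold lower number from compound 2 to compound 4 (0.48 log units; beyond the scatter). Compound 4 is therefore estimated to give 20000 nM, expected to fall between 6000 nM and 60000 nM.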

Compound 4, half-maximal inhibitory concentration: > 100000 nM
Compound 4: no number, only a limit; the forecaster's own chance of this, stated with the estimate: 5%; middle value at least 5.0-fold (0.69 log units) away from the limit.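

In this assay compound 4 gives > 100000 nM, which is a limit of the assay and not a number. Putting methoxy in place of hydrogen on the aromatic ring gives an at least 1.6-fold higher number from compound 2 to compound 4 (0.21 log units; that floor lies within the scatter), and as that figure is only a floor lying within the scatter, it does not by itself set compound 4 apart from compound 2. Set beside the earlier example, however, the change clearly does not carry from one core to the other as a single fixed step, although two examples cannot show what accounts for the gap, and the true size of the step on compound 2 stays unknown: the same change on two cores in this assay, a 9.4-fold lower number (0.97 log units; beyond the scatter) from compound 1 to compound 3 and an at least 1.6-fold higher number (0.21 log units; that floor lies within the scatter) from compound 2 to compound 4, at least 15-fold (1.18 log units) apart, beyond the scatter of two such steps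

The compounds shown leave open whether the gap follows from where the methoxy enters, from the position of the methoxy already on the ring, or from both, since the two examples differ in these places at once. They also leave open how other groups would behave at the same places on either core, for example an amine, a carboxylic acid or a longer chain such as propoxy in place of the entering methoxy.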